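The source may hold more compounds than are shown below. What is called first, only, known or untested is meant among the compounds shown, and "the series" means these compounds.

Measured compounds in a functional assay on NCI-H226 cells (Homo sapiens) for inhibition, read by MTT assay, with a stated time of 48 h, tested at 10 uM; a higher number here means more inhibition at the concentration tested (going by the name of the read-out), a lower number less inhibition:

Compound 1 `CCc1ccc(Nc2cc(NC(=O)Nc3c(Cl)cccc3Cl)ncn2)cc1`: 39.5%
Compound 2 `COc1cc(Br)ccc1Nc1cc(NC(=O)Nc2c(Cl)cccc2Cl)ncn1`: 43%
Compound 3 `CCc1cccc(Nc2cc(NC(=O)Nc3cc(OC)cc(OC)c3)ncn2)c1`: 36.7%

Compound 3 stands alongside the other two in this assay: its gap to compound 1 and its gap to compound 2 are both within the usual scatter, so the three numbers cannot be told apart with confidence.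

Compound 4 `COc1cc(NC(=O)Nc2cc(Nc3cc(F)ccc3OC)ncn2)cc(OC)c1` has not yet been measured. It differs from compound 3 in one place: 5-fluoro-2-methoxyphenyl in place of 3-ethylphenyl on a nitrogen on an aromatic ring. Among the compounds with values here, the one measured step that bears on this kind of change is the one between compound 1 and compound 2, where 4-bromo-2-methoxyphenyl takes the place of 4-ethylphenyl on the same nitrogen; there a number 3.5 percentage points higher from compound 1 to compound 2 (within the scatter), a change within the scatter. That step, like the present one, swaps an ethyl-bearing phenyl for a methoxy-bearing phenyl carrying a halogen, and it moved the read-out by no more than the scatter. Compound 4 is therefore expected to land near compound 3, with the step from compound 3 to compound 4 estimated at a number 3.3 percentage points higher from compound 3 to compound 4 (within the scatter), a change not beyond the scatter in either direction. Compound 4 is estimated at 40%, within a range from 25% to 55%.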

Compound 4, a percentage reported as inhibition, at one concentration (the size of the read-out at that concentration, not a potency): 37.7%
Estimate against measurement, compound 4: 2.3 percentage points above; the measured number falls inside the stated range.
By their numbers in this assay, from the lowest: compounds 3, 4, 1 and 2 (each within the scatter of the next).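

In this assay the exchange of 3-ethylphenyl for 5-fluoro-2-methoxyphenyl on the nitrogen gives a number 1 percentage points higher from compound 3 to compound 4 (within the scatter) and so leaves the read-out indistinguishable between the two compounds. This is a second exchange of an ethyl-bearing phenyl for a phenyl carrying both methoxy and a halogen at this nitrogen, and it stands on a different remainder of the molecule from a number 3.5 percentage points higher from compound 1 to compound 2 (within the scatter) as the earlier case, so the absence of a change beyond the scatter now holds for both of these pairs. No measurement shown here offers an explanation for this result.

The two steps each alter several features of the ring at once, so they leave open whether the ethyl group, the methoxy group or the halogen alone would shift the number in this assay. On these data alone, it also remains open whether a quite different group on this nitrogen, such as a ring bearing an amine, a carboxylic acid or a longer alkyl chain, would produce a step beyond the scatter.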